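Compound 3 to compound 4: replacing pyrimidin-5-yl

The compounds below may be only part of what the source reports. "The series", "measured", "known", "first", "only" and "open" are said of these compounds alone.

The compounds share one core and differ in the group on a saturated chain carbon bound to an amide-type nitrogen and a saturated chain carbon. In an in vivo ADME assay on the whole organism for pharmacokinetics, with Canis familiaris (Canis lupus familiaris) as the target (on this read-out higher numbers stand for higher oral bioavailability and lower numbers for lower oral bioavailability), compound 1 `O=C(O)C[C@H](NC(=O)CCCCc1ccc2c(n1)NCCC2)c1ccc2c(c1)OCC2` gives 99% and compound 2 `O=C(O)C[C@H](NC(=O)CCCCc1ccc2c(n1)NCCC2)c1cccc(F)c1` gives 81%. Compound 3 `O=C(O)C[C@H](NC(=O)CCCCc1ccc2c(n1)NCCC2)c1cncnc1` gives 10%, the lowest of the three numbers. Compound 4 `O=C(O)C[C@H](NC(=O)CCCCc1ccc2c(n1)NCCC2)c1ccc2nc(O)oc2c1` is not yet measured and differs from compound 3 as follows: 2-hydroxy-1,3-benzoxazol-6-yl in place of pyrimidin-5-yl on a saturated chain carbon bound to an amide-type nitrogen and a saturated chain carbon. In short, 2-hydroxy-1,3-benzoxazol-6-yl stands in place of pyrimidin-5-yl.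

Two large measured steps bear on this change: a number 89 percentage points lower from compound 1 to compound 3 (beyond the scatter), and a number 71 percentage points lower from compound 2 to compound 3 (beyond the scatter). The third is smaller: a number 18 percentage points lower from compound 1 to compound 2 (beyond the scatter). Like the group of compound 1, the entering group has a five-membered ring and a six-membered aromatic ring of carbon only. Going by the values given here, its five-membered ring is aromatic with 2 hetero atoms, however, and no measured compound carries that group, so the comparison is loose. A large upward move in this assay is therefore expected, though probably not the full distance to compound 1. The expected step is a number 50 percentage points higher from compound 3 to compound 4 (beyond the scatter). For compound 4 the estimated value is 60%, with an expected range from 30% to 90%.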

Compound 4, oral bioavailability: 25%
Beside the measured number, compound 4's estimate is 35 percentage points above it, outside the stated range (below it).
By their numbers in this assay, from the lowest: compound 3; then compound 4; then compound 2; then compound 1.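

In this assay, a five-membered ring together with a six-membered aromatic ring of carbon only does not by itself carry a high number at this place on a saturated chain carbon bound to an amide-type nitrogen and a saturated chain carbon: both compound 1 and compound 4 have that ring count, yet the record reads a number 74 percentage points lower from compound 1 to compound 4 (beyond the scatter). The entering 2-hydroxy-1,3-benzoxazol-6-yl recovers only a small part of what pyrimidin-5-yl loses, with a number 15 percentage points higher from compound 3 to compound 4 (beyond the scatter) set against a number 56 percentage points lower from compound 2 to compound 4 (beyond the scatter), so among these four compounds a larger bicyclic group does not rank above the single-ring 3-fluorophenyl. Nothing in hand explains this difference in oral exposure.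

Still open, as far as these compounds go, is whether the low number follows the hydroxy group or the five-membered aromatic ring with its two hetero atoms, and a 2-methyl-1,3-benzoxazol-6-yl or an unsubstituted phenyl in the same place would help to separate the two. Also open, from the compounds shown here alone, is whether this order of groups would hold with an ester in place of the carboxylic acid or with a shorter chain in the shared core.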